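The source may hold more compounds than are shown below. What is called first, only, known or untested is meant among the compounds shown, and "the series" means these compounds.

Working notes on the series

The shared core carries a bis(trifluoromethyl)phenylsulfonamide on a three-carbon chain ending in an amine, and the amine substituent is the point that varies. Among the measured compounds shown here, compound 1 `O=S(=O)(NCCCNCc1ccccc1Cl)c1cc(C(F)(F)F)cc(C(F)(F)F)c1` is the weakest of the three measured members: in a functional assay on BXPC-3 cells (Homo sapiens) for inhibition, read by MTT assay, with a stated time of 72 h (a higher number here means a weaker inhibitor of growth, a lower number a stronger inhibitor of growth), compound 1 gives 11000 nM, the highest of the numbers so far. Compound 2 `CC(C)(C)c1ccc(CNCCCNS(=O)(=O)c2cc(C(F)(F)F)cc(C(F)(F)F)c2)cc1` gives 1400 nM and compound 3 `O=S(=O)(NCCCNCC1COc2ccccc2O1)c1cc(C(F)(F)F)cc(C(F)(F)F)c1` gives 1200 nM; these two sit within the scatter of one another. Both measured steps away from compound 1 replaced the 2-chlorophenyl on the chain carbon bound to the amine nitrogen and both lowered the number, a 7.9-fold lower number from compound 1 to compound 2 (0.90 log units; beyond the scatter) and a 9.2-fold lower number from compound 1 to compound 3 (0.96 log units; beyond the scatter).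

Compound 4 `CN(CCCNS(=O)(=O)c1cc(C(F)(F)F)cc(C(F)(F)F)c1)Cc1ccccc1` is not yet measured. It differs from compound 1 by benzyl(methyl)amino in place of (2-chlorobenzyl)amino on a saturated chain carbon, three bonds along the chain from a sulfonamide nitrogen: the chlorine leaves and a methyl enters on the amine nitrogen, so a hydrogen-bond donor is lost. For the measured compounds named here, no measured step touches the amine nitrogen itself, and none removes the chlorine alone; only the two steps from compound 1 to compound 2 and to compound 3 bear on it, and they say that changing the group at this position can lower the number modestly. On that basis a modest lowering is expected for compound 4, a 2.2-fold lower number from compound 1 to compound 4 (0.34 log units; beyond the scatter), with wide uncertainty. The estimate for compound 4 in this assay is 5000 nM, expected to fall between 1500 nM and 20000 nM.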

Compound 4, concentration for 50% growth inhibition: 39000 nM
For compound 4 the middle estimate is 7.8-fold (0.89 log units) below the measured one, and the stated range ends below it.
By their numbers in this assay, from the lowest: compounds 3 and 2 (each within the scatter of the next); then compound 1; then compound 4.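

In this assay, benzyl(methyl)amino in place of (2-chlorobenzyl)amino gives a 3.5-fold higher number from compound 1 to compound 4 (0.55 log units; beyond the scatter), so changes at this position do not only lower the number: the two earlier steps away from compound 1 both went downward, and this one goes upward while the aromatic ring and the heavy-atom count of the group stay the same. The change joins two edits in a single step, the chlorine leaving and a methyl entering on the amine nitrogen with the loss of a hydrogen-bond donor, and this one step cannot divide the rise between them. No measurement at hand bears on why the number rises here.

A plain benzylamino group, carrying neither the chlorine nor the methyl, would separate the two edits, and an ethyl group on the amine nitrogen would test whether the rise is particular to methyl. Also open, from the compounds shown here alone, is whether a methyl on the amine nitrogen would raise the number in the same way with the 4-(tert-butyl)phenyl of compound 2 or the 2,3-dihydro-1,4-benzodioxin-2-yl of compound 3.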